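Dichlorophenyl ether to thioether on the diamine core

The compounds below may be only part of what the source reports. "The series", "measured", "known", "first", "only" and "open" are said of these compounds alone.

Measured compounds in a functional assay on HCT-116 cells (Homo sapiens) for inhibition, read by sulforhodamine B assay, with a stated time of 48 h; a higher number here means a weaker inhibitor of growth, a lower number a stronger inhibitor of growth:
compound 1 `Nc1cc(N)c2nc(-c3ccccc3)c(Oc3ccc(Cl)c(Cl)c3)nc2c1` — 47900 nM
compound 2 `CCOC(=O)[C@H](CCC(=O)O)NC(=O)c1ccc(CNc2nc3cc(N)cc(N)c3nc2-c2ccccc2)cc1` — < 100000 nM
compound 3 `COc1cc(CNc2nc3cc(N)cc(N)c3nc2-c2ccccc2)cc(OC)c1OC` — 19100 nM

Compound 1 holds the highest of the two numbers measured in this assay; its nearest neighbour is compound 3, whose number sits lower by a gap beyond the usual scatter. For compound 2 only a limit is available, not a number, and it stands at the limit of < 100000 nM in this assay, at which 1 of the 3 values shown sits. Among the compounds with values here, no pair among the measured compounds differs in one place, so nothing here tells how a single change on this core shifts the read-out.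

Compound 4 `Nc1cc(N)c2nc(-c3ccccc3)c(Sc3ccc(Cl)c(Cl)c3)nc2c1` is the next analogue of compound 1. The change is (3,4-dichlorophenyl)sulfanyl in place of 3,4-dichlorophenoxy on an aromatic carbon. The (3,4-dichlorophenyl)sulfanyl group replaces the 3,4-dichlorophenoxy group on the aromatic carbon that neighbours the ring nitrogen and sits ortho to the phenyl group. Within the data shown here, no measured step speaks to an oxygen-for-sulfur exchange, so the expected step is small: no shift beyond the scatter, in either direction. The step from compound 1 to compound 4 is estimated at a 1.2-fold lower number from compound 1 to compound 4 (0.08 log units; within the scatter). Compound 4 is therefore expected to give about 40000 nM in this assay, with a range from 15000 nM to 100000 nM.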

Compound 4, concentration for total growth inhibition: 47900 nM
Compound 4: the middle estimate sits 1.2-fold (0.08 log units) below what was measured; the range from low to high includes it.
By their numbers in this assay, from the lowest: compound 3; then compounds 1 and 4 (each within the scatter of the next).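

Within the data shown here, the first step that changes one place reads no change at the digits printed from compound 1 to compound 4 (within the scatter) in this assay, with (3,4-dichlorophenyl)sulfanyl in place of 3,4-dichlorophenoxy on the aromatic carbon next to the ring nitrogen. With the 3,4-dichlorophenyl ring and the rest of the core held constant, this read-out does not separate the oxygen link from the sulfur link at this position, at least for this one pair. No measurement shown offers a reason for this outcome.

On these data alone, what a nitrogen link carrying the same 3,4-dichlorophenyl ring, or a sulfonyl group in place of the sulfanyl sulfur, would do at this position stays open, so the tolerance of this position beyond oxygen and sulfur is unknown. Also open, as far as these compounds go, is whether the exchange of oxygen for sulfur reads the same with a different aryl group, such as an unsubstituted phenyl or a 4-methoxyphenyl, as the present step rests on compound 1 and compound 4 alone.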